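An acetyl group on the aniline nitrogen of compound 3

The compounds below may be only part of what the source reports. "The series", "measured", "known", "first", "only" and "open" are said of these compounds alone.

For the measured compounds named here, compound 3 `CC[C@H](C)[C@H](N)CN(C(=O)[C@@H]1C[C@H]1c1ccccc1)c1ccc(-c2ccc(N)cc2)cc1` gives 320 nM in a functional assay for agonist activity at G protein-coupled receptor 88 (Homo sapiens), read by HTRF and cAMP accumulation (on this read-out lower numbers stand for an effect already at smaller amounts and higher numbers for an effect only at larger amounts of compound), the highest of the three numbers measured so far. Compound 1 `CC[C@H](C)[C@H](N)CN(C(=O)[C@@H]1C[C@H]1c1ccccc1)c1ccc(-c2ccc(OC(C)C)cc2)cc1` gives 72 nM and compound 2 `CC[C@H](C)[C@H](N)CN(C(=O)[C@@H]1C[C@H]1c1ccccc1)c1ccc(-c2ccc(Oc3ccccc3)cc2)cc1` gives 94 nM; these two lie within the scatter of each other, a 1.3-fold higher number from compound 1 to compound 2 (0.12 log units; within the scatter). From either of them to compound 3 the number rises: a 4.4-fold higher number from compound 1 to compound 3 (0.65 log units; beyond the scatter) and a 3.4-fold higher number from compound 2 to compound 3 (0.53 log units; beyond the scatter).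

Compound 4 `CC[C@H](C)[C@H](N)CN(C(=O)[C@@H]1C[C@H]1c1ccccc1)c1ccc(-c2ccc(NC(C)=O)cc2)cc1` differs from compound 3 by acetyl in place of hydrogen on a nitrogen on an aromatic ring. Going by the values given here, no measured step alters this nitrogen itself. Among the compounds with values here, the steps that bear on the position are the two in which isopropoxy or phenoxy gave way to the amino group, and both raised the number by a modest amount beyond the scatter. They show that a substituent other than a plain amino group at this position went with a lower number, while compound 4 keeps the nitrogen and adds an acetyl group to it. For compound 4 a modest step down in this assay is therefore expected, a 2.0-fold lower number from compound 3 to compound 4 (0.30 log units; within the scatter), on this indirect basis. A result within the scatter of compound 3 would not be surprising. Compound 4 is estimated at 160 nM, with a range from 50 nM to 500 nM.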

Compound 4, half-maximal effective concentration: 5500 nM
Compound 4: the middle estimate sits 34-fold (1.54 log units) below what was measured; the measured number lies above the stated range.
By their numbers in this assay, from the lowest: compounds 1 and 2 (each within the scatter of the next); then compound 3; then compound 4.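

In this assay, for the compounds shown here, acetyl in place of hydrogen on the nitrogen on the aromatic ring gives a 17-fold higher number from compound 3 to compound 4 (1.24 log units; beyond the scatter), the first measured change to this nitrogen itself, and it shows that this position can respond far more strongly than the earlier steps indicated. Measured against the two oxygen-linked groups, acetamido lies further still, with a 59-fold higher number from compound 2 to compound 4 (1.77 log units; beyond the scatter) and a 76-fold higher number from compound 1 to compound 4 (1.88 log units; beyond the scatter), whereas isopropoxy, phenoxy and amino were separated by steps that were either within the scatter or only modest. Nothing among the data available gives a reason for a step of this size.

From the compounds shown here alone, it remains open whether the large rise goes with the acetyl group specifically or with any group placed on this nitrogen, a question that a methyl group, a methanesulfonyl group or a longer acyl chain such as propanoyl on the same nitrogen would help to settle. Going by these compounds, it also remains open whether a urea or a reversed amide at this place on the aromatic ring would follow acetamido or stay closer to amino.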